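The source may report more compounds than this note shows. Statements on the series, on what has been measured and on what is new or still open speak of the compounds shown alone.

Compound 1 `CCc1cccc(NC(=O)C(=O)[C@H](CC(C)C)NC(=O)[C@H](CC(C)C)NC(=O)[C@H](CC(C)C)NC(=O)OCc2ccccc2)c1`: 78.5 nM
Compound 2 `COc1cc(NC(=O)C(=O)[C@H](CC(C)C)NC(=O)[C@H](CC(C)C)NC(=O)[C@H](CC(C)C)NC(=O)OCc2ccccc2)cc(OC)c1`: 68.5 nM

Both values come from a functional assay on MGC-803 cells (Homo sapiens) for antiproliferative activity, read by MTT assay, with a stated time of 72 h; a higher number here means a weaker inhibitor, a lower number a stronger inhibitor. Among the compounds with values here, compound 2 stands within the usual scatter of compound 1, the only other compound measured so far, so neither can be ranked above the other. Compound 3 `CC(C)C[C@H](NC(=O)OCc1ccccc1)C(=O)N[C@@H](CC(C)C)C(=O)N[C@@H](CC(C)C)C(=O)C(=O)Nc1ccccc1` keeps the shared core of compound 2 and changes one group: phenyl in place of 3,5-dimethoxyphenyl on an amide-type nitrogen. This puts phenyl in place of 3,5-dimethoxyphenyl on an amide-type nitrogen. Within the data shown here, only one measured step bears on this swap, as it also exchanges the group on that nitrogen: a 1.1-fold lower number from compound 1 to compound 2 (0.06 log units; within the scatter). On that single step, no change beyond the scatter is expected in this assay, in either direction. Among the measured compounds shown here, no measured compound yet carries the plain phenyl, so the range must stay wide. The expected change is a 1.1-fold higher number from compound 2 to compound 3 (0.04 log units; within the scatter). For compound 3 the estimated value is 75 nM, with an expected range of 30 nM to 190 nM.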

Compound 3, half-maximal inhibitory concentration: 119 nM
Beside the measured number, compound 3's estimate is 1.6-fold (0.20 log units) below it, within the range that was stated.
By their numbers in this assay, from the lowest: compounds 2, 1 and 3 (each within the scatter of the next).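

In this assay, stripping the ring on the amide-type nitrogen down to plain phenyl gives a 1.7-fold higher number from compound 2 to compound 3 (0.24 log units; within the scatter), and the same holds for the swap of ethyl for hydrogen on the ring, a 1.5-fold higher number from compound 1 to compound 3 (0.18 log units; within the scatter). With 3-ethylphenyl, 3,5-dimethoxyphenyl and phenyl now all tested at this position, neither ring substituent has shifted the number beyond the scatter, so the three compounds cannot be ranked. No measurement shown here offers an explanation for these numbers.

The compounds shown leave open whether an amine or a carboxylic acid on the ring, or a cyclohexyl group in place of the aromatic ring, would give a clearer difference. The rest of the shared core is identical in all three compounds, so they say nothing about changes there.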